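This account rests on a few compounds, and the source may have more. Where it says the series, first, only, none or still open, it means among the compounds named here.

Measured compounds in a functional assay on NCI-H226 cells (Homo sapiens) for inhibition, read by sulforhodamine B assay, with a stated time of 48 h; a higher number here means a weaker inhibitor of growth, a lower number a stronger inhibitor of growth:
compound 1 `COc1cc(OC)cc(-c2ccc(-c3ccc(C(=N)N)c(F)c3)s2)c1` gives 1730 nM
compound 2 `N=C(N)c1ccc(-c2ccc(-c3ccc(Cl)cc3)s2)cc1F` gives 2030 nM
compound 3 `N=C(N)c1ccc(-c2ccc(-c3ccc(Cl)cc3)s2)cc1` gives 451 nM

Compound 1 and compound 2 carry different cores; the difference between the two cores is not broken down here. The values of compound 1 and compound 2 lie within the scatter of each other. From compound 2 to compound 3 the change is hydrogen in place of fluoro on an aromatic carbon, and it gave a 4.5-fold lower number from compound 2 to compound 3 (0.65 log units; beyond the scatter).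

Compound 4 `COc1cc(OC)cc(-c2ccc(-c3ccc(C(=N)N)cc3)s2)c1` is not yet measured. It stands to compound 1 as compound 3 stands to compound 2: the change is hydrogen in place of fluoro on an aromatic carbon, the same change at a place described in the same words. The expectation for compound 4 rests on that one pair, compound 2 and compound 3, and on their step of a 4.5-fold lower number from compound 2 to compound 3 (0.65 log units; beyond the scatter); nothing else in the series tests this change, and the two cores differ. The step from compound 1 to compound 4 is therefore expected at a 3.8-fold lower number from compound 1 to compound 4 (0.58 log units; beyond the scatter), kept a little short of the earlier one. Compound 4 is estimated at 450 nM in this assay, with the likely range from 200 nM to 1000 nM.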

Compound 4, concentration for 50% growth inhibition: 2230 nM
Compound 4: the middle estimate sits 5.0-fold (0.70 log units) below what was measured; the whole stated range lies below it.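

In this assay, hydrogen in place of fluoro on an aromatic carbon does not carry over as a fixed step between these two cores: the same change on two cores in this assay, a 4.5-fold lower number (0.65 log units; beyond the scatter) from compound 2 to compound 3 and a 1.3-fold higher number (0.11 log units; within the scatter) from compound 1 to compound 4, 5.8-fold (0.76 log units) apart, beyond the scatter of two such steps. On the core of compound 1 the change gives a 1.3-fold higher number from compound 1 to compound 4 (0.11 log units; within the scatter), so the fluoro group makes no readable difference on this core, and the step seen on the core of compound 3 cannot be used as a general increment for the series. Within the data shown here, with only two pairs, this shows that the step depends on the core, but not which part of the core is responsible, nor which of the two steps would be more typical on a third core.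

As far as these compounds go, it remains open how the same change reads on cores carrying a nitrile, a hydroxyl or an amine in place of the chloro or the two methoxy groups, and whether such steps would fall close to either pair. Also open, from the compounds shown here alone, is how a methyl group or a hydroxyl at the same aromatic carbon would compare with fluoro and hydrogen on each core.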